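Removing One Chloro Group from a Ghrelin Receptor Antagonist

The compounds below may be only part of what the source reports. "The series", "measured", "known", "first", "only" and "open" are said of these compounds alone.

Compound 1, `Cc1cc2c(cc1Cl)NC(=O)C2(NC(=O)CN1CCN(C)CC1)c1ccc(Cl)cc1Cl`: > 10000 nM
Compound 2, `Cc1cc2c(cc1Cl)NC(=O)C2(NC(=O)CN1CCN(C)CC1)c1ccccc1Cl`: > 10000 nM
Compound 3, `CN1CCN(CC(=O)NC2(c3ccc(Cl)cc3)C(=O)Nc3cc(Cl)cc(Cl)c32)CC1`: 72 nM

All three were tested in an in vitro functional assay on CHO-CREluc cells for antagonist activity at growth hormone secretagogue receptor type 1 (Homo sapiens), read by a luciferase reporter, with a stated time of 4 h; on this read-out lower numbers stand for stronger inhibition and higher numbers for weaker inhibition. For compound 1 the value is a limit of the assay, not a number. The same holds for compound 2. Going by the values given here, compound 3 gives the only number in this assay. The difference between the core of compound 1 and that of compound 3 is not broken down here.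

From compound 1 to compound 2 the change is hydrogen in place of chloro on an aromatic carbon, and the step is a step that the two limits leave unreadable from compound 1 to compound 2, since both values sit at the limit of > 10000 nM in this assay, at which 2 of the 3 values shown sit.

Compound 4, `CN1CCN(CC(=O)NC2(c3ccc(Cl)cc3)C(=O)Nc3cc(Cl)ccc32)CC1`, is not yet measured. It differs from compound 3 by hydrogen in place of chloro on an aromatic carbon. This is the same kind of change as from compound 1 to compound 2, but its place differs: here the carbon is part of a fused or bridged system of two rings, ortho to a fused ring and meta to a fused ring, whereas before it was para to a large group.

Because the step that the two limits leave unreadable from compound 1 to compound 2 cannot be read, no measured guide exists, so compound 4 is estimated at 250 nM, a step of a 3.5-fold higher number from compound 3 to compound 4 (0.54 log units; beyond the scatter), with a wide range from 60 nM to 2000 nM expected.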

Compound 4, half-maximal inhibitory concentration: 140 nM
Compound 4: the middle estimate sits 1.8-fold (0.25 log units) above what was measured; the range from low to high includes it.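

In this assay, hydrogen in place of chloro on an aromatic carbon gives a 1.9-fold higher number from compound 3 to compound 4 (0.29 log units; within the scatter), so at this place on this core the swap cannot be told apart from the ordinary spread of repeated measurements. The same kind of change on the core of compound 1, at a different place on the molecule, cannot be read, because compound 1 and compound 2 both sit at a limit of the assay rather than at a number: the limit of > 10000 nM in this assay, at which 2 of the 4 values shown sit.

The two cases therefore cannot be compared, and the data do not show whether the effect of this change carries from one core to another, so the result applies only to this one place on this one core.

The compounds shown leave open what a fluoro, methoxy or nitrile group would do at this aromatic carbon, where only chloro and hydrogen appear. Also open, on these data alone, is what would follow from replacing the chloro group that remains meta to this carbon in compound 4.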